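Solubility notes on side-chain changes in the series of compound 1

This account rests on a few compounds, and the source may have more. Where it says the series, first, only, none or still open, it means among the compounds named here.

compound 1 `O=C1CCC(=O)N1C[C@H]1CN(c2ccc(-n3cc(-c4ccccn4)cn3)c(F)c2)C(=O)O1` 45300 nM
compound 2 `CS(=O)(=O)NC[C@H]1CN(c2ccc(-n3cc(-c4ccccn4)cn3)c(F)c2)C(=O)O1` 2300 nM

In a physicochemical assay for solubility, read by HPLC, with a stated time of 24 h (a lower number here means a less soluble compound, a higher number a more soluble compound), compound 1 gives 45300 nM, the highest of the two numbers recorded so far; its nearest neighbour is compound 2, which in this assay gives 2300 nM. Among the compounds with values here, the single measured step is a 20-fold lower number from compound 1 to compound 2 (1.29 log units; beyond the scatter), a methanesulfonamido in place of 2,5-dioxopyrrolidin-1-yl on a saturated chain carbon bound to a saturated ring carbon.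

Compound 3 `CNC(=O)[C@H]1CN(c2ccc(-n3cc(-c4ccccn4)cn3)c(F)c2)C(=O)O1` is not yet measured. It differs from compound 1 as follows: methylcarbamoyl in place of (2,5-dioxopyrrolidin-1-yl)methyl on a saturated ring carbon. Within the data shown here, only the step from compound 1 to compound 2 bears on this, and only loosely, since it concerns a different site and a different entering group; it was large and downward. A downward step of smaller size is therefore expected for compound 3, as a 3.0-fold lower number from compound 1 to compound 3 (0.48 log units; beyond the scatter). Compound 3 is estimated at 15000 nM, with a range of 4000 nM to 60000 nM.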

Compound 3, solubility: 26200 nM
Compound 3: the middle estimate sits 1.7-fold (0.24 log units) below what was measured, within the range that was stated.
By their numbers in this assay, from the lowest: compound 2; then compounds 3 and 1 (each within the scatter of the next).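

In this assay, the step of a 1.7-fold lower number from compound 1 to compound 3 (0.24 log units; within the scatter) sits within the scatter, so at this saturated ring carbon, methylcarbamoyl, with no ring, can stand in place of (2,5-dioxopyrrolidin-1-yl)methyl without a readable change in the number. The same position gives an 11-fold higher number from compound 2 to compound 3 (1.06 log units; beyond the scatter), which leaves compound 2 as the only one of the three set apart from the others by a step beyond the scatter. Nothing at hand accounts for either step.

Compound 3 differs from compound 2 both in the sulfonamide and in the saturated chain carbon, so these two features cannot be separated here. As far as these compounds go, how an amine, a carboxylic acid or a longer chain ending in an amide would stand at this ring carbon in this assay also remains open.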